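Vinyl to fluoro on a sulfonamide: cytotoxicity expectation

The compounds below may be only part of what the source reports. "The series", "measured", "known", "first", "only" and "open" are said of these compounds alone.

Measured so far:
- Compound 1 `C=Cc1ccc(S(=O)(=O)Nc2ccc(-c3nc4ccccc4o3)cc2)cc1`: in an ADME assay on HEK293 cells (Homo sapiens) for cytotoxicity, read by resazurin assay, with a stated time of 48 h (on this read-out higher numbers stand for lower toxicity in this test and lower numbers for higher toxicity in this test), compound 1 gives > 100000 nM, which is a limit of the assay and not a number.
- Compound 2 `O=S(=O)(Nc1ccc2oc(-c3ccccc3)nc2c1)c1ccc(F)c(C(F)(F)F)c1`: in this assay compound 2 gives > 100000 nM, likewise a limit of the assay.

Where compound 1 stands is therefore only known as a limit, and the one other value on record is also a limit. Among the compounds with values here, both values sit at the limit of > 100000 nM in this assay, at which 2 of the 2 values shown sit, so no gap between compounds has been measured here, and no step between measured compounds exists to lean on.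

Compound 3 `O=S(=O)(Nc1ccc(-c2nc3ccccc3o2)cc1)c1ccc(F)cc1` has not yet been tested. It differs from compound 1 by fluoro in place of vinyl on an aromatic carbon, a change of a small group at one place on a ring of the shared core. Within the data shown here, with no measured step to compare, the expected step from compound 1 to compound 3 in this assay is one of no change beyond the scatter, since compound 1 and compound 2 both sit at the limit of > 100000 nM in this assay, at which 2 of the 2 values shown sit. The step from compound 1 to compound 3 is expected to be a step that the limit leaves unreadable from compound 1 to compound 3. Compound 3 is therefore estimated to give 150000 nM, within 50000 nM to 500000 nM, most likely again reported only as a limit.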

Compound 3, half-maximal cytotoxic concentration: > 100000 nM
Compound 3 gave a limit, no number; the forecaster's own chance of this, stated with the estimate: 80%; the middle value does not contradict the limit.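

Compound 1 and compound 3 each end at a limit of the assay and not at a number, so no size can be read for the change from vinyl to fluoro in this assay: the limit of > 100000 nM in this assay, at which 3 of the 3 values shown sit. The compounds shown leave open how far each one lies from that limit, and what change to the shared core would yield a readable value.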